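The source may hold more compounds than are shown below. What is called first, only, known or untested is meant among the compounds shown, and "the series" means these compounds.

Measured compounds in a functional assay on BJAB cells (Homo sapiens) for antiproliferative activity, with a stated time of 4 days; on this read-out higher numbers stand for an effect only at larger amounts of compound and lower numbers for an effect already at smaller amounts:
compound 1 `COc1cncc(-c2c(C)nn(-c3nc(-c4ccc(Cl)c(Cl)c4)c(SC(C)C)s3)c2C(=O)O)c1` gives 21000 nM
compound 2 `CCOc1ncccc1-c1c(C)nn(-c2nc(-c3ccc(Cl)c(Cl)c3)c(SC(C)C)s2)c1C(=O)O` gives 11000 nM
compound 3 `Cc1ccc(-c2c(C)nn(-c3nc(-c4ccc(Cl)c(Cl)c4)c(SC(C)C)s3)c2C(=O)O)cc1` gives 3800 nM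

Compound 3 has the lowest number of the three; the step of a 2.9-fold lower number from compound 2 to compound 3 (0.46 log units; beyond the scatter) and the step of a 5.5-fold lower number from compound 1 to compound 3 (0.74 log units; beyond the scatter) both lie beyond the scatter, while a 1.9-fold lower number from compound 1 to compound 2 (0.28 log units; within the scatter) stays within it. Compound 4 `Cc1nn(-c2nc(-c3ccc(Cl)c(Cl)c3)c(SC(C)C)s2)c(C(=O)O)c1-c1cnn(C)c1` is not yet measured. Its change from compound 3 is 1-methyl-1H-pyrazol-4-yl in place of 4-methylphenyl on an aromatic carbon. The two steps that bear on it are those in which a 4-methylphenyl replaced a pyridyl group, a 5.5-fold lower number from compound 1 to compound 3 (0.74 log units; beyond the scatter) and a 2.9-fold lower number from compound 2 to compound 3 (0.46 log units; beyond the scatter), both going to a lower number. Moving from 4-methylphenyl to another nitrogen-containing ring, the 1-methyl-1H-pyrazol-4-yl, is therefore expected to bring a modest step to a higher number, a 3.2-fold higher number from compound 3 to compound 4 (0.50 log units; beyond the scatter). Compound 4 is estimated at 12000 nM, within 5000 nM to 30000 nM.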

Compound 4, half-maximal effective concentration: 6800 nM
For compound 4 the middle estimate is 1.8-fold (0.25 log units) above the measured one; measured number inside the range.
By their numbers in this assay, from the lowest: compounds 3, 4, 2 and 1 (each within the scatter of the next, the first and the last beyond it).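

For the compounds shown here, at this position the 1-methyl-1H-pyrazol-4-yl group stays close to two others, with a 1.8-fold higher number from compound 3 to compound 4 (0.25 log units; within the scatter) and a 1.6-fold lower number from compound 2 to compound 4 (0.21 log units; within the scatter), yet it separates from 5-methoxypyridin-3-yl, with a 3.1-fold lower number from compound 1 to compound 4 (0.49 log units; beyond the scatter) as the one clear step. Unlike the pyridyl groups of compound 1 and compound 2, whose steps to compound 3 lie beyond the scatter, this nitrogen-bearing ring stays within the scatter of the 4-methylphenyl group of compound 3, so ring nitrogen alone does not set the number apart. Nothing measured here accounts for these steps.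

Open remains how an amine or a longer chain on the pyrazole, or a plain phenyl at this position, would read.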